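Methyl removal on the core of compound 1

The source may hold more compounds than are shown below. What is called first, only, known or untested is meant among the compounds shown, and "the series" means these compounds.

Compound 1 `C[C@H]1N=C2C[C@H]3C[C@H](C3(C)C)[C@@]2(C)OC1=O` gives the lowest of the two numbers measured in a functional assay on EL4 cells (Mus musculus) for antiproliferative activity, read by sulforhodamine B assay, with a stated time of 48 h (a lower number here means a stronger inhibitor, a higher number a weaker inhibitor), at 27000 nM. Compound 2 `CC(C)(C)OC(=O)n1cnc(C[C@H]2N=C3C[C@H]4C[C@H](C4(C)C)[C@@]3(C)OC2=O)c1`, which carries a larger group at the same place, gives 139000 nM in this assay, a weaker result beyond the scatter. Compound 3 `CC1(C)[C@H]2CC3=NCC(=O)O[C@]3(C)[C@@H]1C2` is not yet measured. It differs from compound 1 as follows: hydrogen in place of methyl on a saturated ring carbon. Going by the values given here, no step of this kind has been measured, so the expected step from compound 1 to compound 3 is estimated as a 1.5-fold higher number from compound 1 to compound 3 (0.17 log units; within the scatter), small and likely within or near the scatter. Compound 3 is estimated at 40000 nM, with a range from 12000 nM to 130000 nM.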

Compound 3, half-maximal inhibitory concentration: > 300000 nM
Compound 3 ended at the assay's limit; the forecaster's own chance of this, stated with the estimate: 15%; middle value at least 7.5-fold (0.87 log units) away from the limit.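

In this assay, hydrogen in place of methyl on this saturated ring carbon, next to the ring nitrogen, gives an at least 11-fold higher number from compound 1 to compound 3 (1.04 log units; beyond the scatter), so this position is sensitive to removal as well as to enlargement. On these data alone, compound 3 stands at a limit of the assay, > 300000 nM, not at a number, so the full size of the step stays unknown: the limit of > 300000 nM in this assay, at which 1 of the 3 values shown sits. Compound 1, with methyl, now holds the lowest number among both the smaller and the larger substituents shown. Open, as far as these compounds go, is how an ethyl group, a short chain ending in an amine or one ending in a carboxylic acid would read at this carbon.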